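The source may hold more compounds than are shown below. What is called first, only, known or untested is meant among the compounds shown, and "the series" means these compounds.

In a functional assay on SW480 cells (Homo sapiens) for cytotoxicity, read by MTT assay, with a stated time of 48 h (a higher number here means a weaker inhibitor, a lower number a stronger inhibitor), compound 1 `CCOC(=O)[C@]1(C(=O)Nc2ccccc2)C[C@@H]1c1cc(OC)c(OC)c(OC)c1` gives 31700 nM and compound 2 `CCOC(=O)[C@]1(C(=O)NCc2ccc(C)cc2)C[C@H]1c1cc(OC)c(OC)c(OC)c1` gives 36400 nM, so the two lie within the scatter of each other. Compound 3 `CCOC(=O)[C@]1(C(=O)NCc2ccc(C)cc2)C[C@@H]1c1cc(OC)c(OC)c(OC)c1` remains unmeasured. Its difference from compound 2 is the two compounds have the same atoms and bonds and differ only in configuration as drawn: 1 of 2 stereo elements differ; a stereocentre at a saturated ring carbon is drawn S in compound 2 and R in compound 3: a stereocentre at a saturated ring carbon is drawn S in compound 2 and R in compound 3. Within the data shown here, no measured pair isolates this change, so no step beyond the scatter is expected in this assay, in either direction. The estimated step is a 1.1-fold lower number from compound 2 to compound 3 (0.06 log units; within the scatter). For compound 3 the expected value is 32000 nM, with an estimated range of 14000 nM to 75000 nM.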

Compound 3, half-maximal inhibitory concentration: > 100000 nM
Compound 3: only a limit was reported (the forecaster's own chance of this, stated with the estimate: 15%); at least 3.1-fold (0.49 log units) between middle value and limit.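

Drawing the saturated ring carbon R instead of S, with atoms and bonds unchanged, gives an at least 2.7-fold higher number from compound 2 to compound 3 (0.43 log units; beyond the scatter) in this assay, the first sign that configuration at this position counts in this assay. With that carbon drawn R, 4-methylbenzyl in place of phenyl on the amide-type nitrogen gives an at least 3.1-fold higher number from compound 1 to compound 3 (0.49 log units; beyond the scatter), although compound 1 and compound 2 had lain within the scatter of each other. The result for compound 3 is only a limit: the limit of > 100000 nM in this assay, at which 1 of the 3 values shown sits.

From the compounds shown here alone, how large either step really is stays open. So does whether a longer alkyl chain or an aminomethyl group on the amide-type nitrogen would show the same dependence on configuration.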